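Notes on the step from compound 1 to compound 4

A few compounds are considered here, and "the series" means these few. Any claim that something is new, unique, unknown or untested is made for them only; others in the source may bear on it.

- Compound 1 `COCC(=O)N(Cc1ccc(OC)c(O)c1)c1cc(OC)c(OC)c(OC)c1`: 79 nM
- Compound 2 `COc1ccc(CNc2cc(OC)c(OC)c(OC)c2)cc1Cl`: 46200 nM
- Compound 3 `COc1cc(NCc2ccc(Cl)cc2)cc(OC)c1OC`: > 80000 nM, a limit of the assay

All three compounds were read in a functional assay on MGC-803 cells (Homo sapiens) for inhibition, read by MTT assay, with a stated time of 48 h; on this read-out lower numbers stand for stronger inhibition and higher numbers for weaker inhibition. Compound 1 stands lowest among the numbers at 79 nM. The nearest number comes from compound 2 at 46200 nM, a gap well beyond the usual scatter. Compound 3 is recorded only as a limit, > 80000 nM.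

Compound 4 `C#CC(=O)N(Cc1ccc(OC)c(O)c1)c1cc(OC)c(OC)c(OC)c1` has not yet been measured in this assay. It carries ethynyl in place of methoxymethyl on a carbonyl carbon. Going by the values given here, no measured pair isolates this change, so the size of its effect has no direct precedent. Compound 4 otherwise keeps the structure of compound 1, which gives 79 nM, so its number is expected to stay in the same region. A modest move towards a higher number is expected, possibly none beyond the scatter, and the estimated step is a 1.6-fold higher number from compound 1 to compound 4 (0.22 log units; within the scatter). The estimate for compound 4 is 130 nM. The expected range for compound 4 runs from 25 nM to 900 nM.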

Compound 4, half-maximal inhibitory concentration: 170 nM
Beside the measured number, compound 4's estimate is 1.3-fold (0.12 log units) below it; measured number inside the range.
By their numbers in this assay, from the lowest: compound 1; then compound 4; then compound 2. At a limit, above all of these: compound 3.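

In this assay, the carbonyl carbon bound to the amide-type nitrogen now has its first measured step: a 2.2-fold higher number from compound 1 to compound 4 (0.33 log units; beyond the scatter), with ethynyl in place of methoxymethyl. The step is modest but beyond the scatter, which shows that this place responds to the change and that the oxygen of methoxymethyl is not needed for activity of this order, as compound 4 still gives 170 nM. The data shown contain no measurement that speaks to the reason for this shift.

This single step changes the chain length, removes the oxygen and introduces the triple bond all at once, so the contribution of each remains unresolved. As far as these compounds go, an ethyl group would separate the triple bond from the chain length, a methoxyethyl group would test a longer chain that keeps the oxygen, and a dimethylaminomethyl group or a carboxylic acid would show how this place responds to an amine or an acid; the values of such compounds relative to compound 1 and compound 4 remain open.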